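The source may hold more compounds than are shown below. What is called first, only, known or untested is meant among the compounds shown, and "the series" means these compounds.

Of the compounds shown here, three sharing one core have been measured in a functional assay on U-251 cells (Homo sapiens) for antiproliferative activity, read by MTT assay, with a stated time of 24 h; a lower number here means a stronger inhibitor, a higher number a weaker inhibitor. Compound 1 `COc1cc(OC)c(-c2coc3cc(OCc4ccccc4F)ccc3c2=O)cc1OC`, which carries 2-fluorophenyl, gives 2890 nM. Compound 2 `COc1cc(OC)c(-c2coc3cc(OCc4ccc(Br)cc4)ccc3c2=O)cc1OC`, which carries 4-bromophenyl, gives 10000 nM. Compound 3 `COc1cc(OC)c(-c2coc3cc(OCc4ccc([N+](=O)[O-])cc4)ccc3c2=O)cc1OC`, which carries 4-nitrophenyl, gives 9400 nM. This puts compound 3 level with compound 2 within the scatter, and both are weaker than compound 1.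

Compound 4 `COc1cc(OC)c(-c2coc3cc(OCc4ccccc4C#N)ccc3c2=O)cc1OC` places 2-cyanophenyl in the spot held by 4-nitrophenyl: 2-cyanophenyl in place of 4-nitrophenyl on a saturated chain carbon bound to an oxygen on an aromatic ring.

Going by the values given here, three measured steps bear on this change. Swapping the aryl group gives a 3.3-fold higher number from compound 1 to compound 3 (0.51 log units; beyond the scatter) and a 3.5-fold higher number from compound 1 to compound 2 (0.54 log units; beyond the scatter), both modest. Replacing bromo with nitro gives a 1.1-fold lower number from compound 2 to compound 3 (0.03 log units; within the scatter), so that change shows no real shift. Among the compounds with values here, no measured compound carries 2-cyanophenyl, and the closest by name is the 2-fluorophenyl of compound 1, at 2890 nM.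

A modest move towards that number is therefore expected, partly undoing the rise seen with compound 3, and the expected step is a 2.1-fold lower number from compound 3 to compound 4 (0.32 log units; beyond the scatter). For compound 4 the estimated value is 4500 nM, with an expected range from 1800 nM to 10000 nM.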

Compound 4, half-maximal inhibitory concentration: 980 nM
For compound 4 the middle estimate is 4.6-fold (0.66 log units) above the measured one, and the stated range ends above it.
By their numbers in this assay, from the lowest: compound 4; then compound 1; then compounds 3 and 2 (each within the scatter of the next).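

In this assay, going by these compounds alone, the aryl group on this saturated chain carbon turns out to have more room for improvement than the earlier compounds suggested: 2-cyanophenyl gives a 9.6-fold lower number from compound 3 to compound 4 (0.98 log units; beyond the scatter) and a 10-fold lower number from compound 2 to compound 4 (1.01 log units; beyond the scatter), leaving compound 4 with the lowest number of the four. Both groups in the comparison with the best earlier compound carry the 2- label, yet cyano in place of fluoro on an aromatic carbon still gives a 2.9-fold lower number from compound 1 to compound 4 (0.47 log units; beyond the scatter), so the identity of this group matters and not only its placement. Nothing available here explains these differences.

On these data alone, compounds 2 and 3 differ from compound 4 in both the group and its placement on the ring, so it remains open whether the lower number follows the nitrile itself or its placement, which 4-cyanophenyl would help separate. As far as these compounds go, how a carboxylic acid or an aminomethyl group would behave on the same ring also remains open.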